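This account rests on a few compounds, and the source may have more. Where it says the series, first, only, none or still open, it means among the compounds named here.

Measured compounds:
Compound 1, `COc1ccc(CNCCCNS(=O)(=O)c2cc(C(F)(F)F)cc(C(F)(F)F)c2)cc1OC`; in a functional assay on MCF7 cells (Homo sapiens) for inhibition, read by MTT assay, with a stated time of 72 h (a higher number here means a weaker inhibitor of growth, a lower number a stronger inhibitor of growth), compound 1 gives 1900 nM.
Compound 2, `O=S(=O)(NCCCNCc1ccc(Br)cc1)c1cc(C(F)(F)F)cc(C(F)(F)F)c1`; in this assay compound 2 gives 1900 nM.

Among the compounds with values here, compound 2 stands level with compound 1 on these numbers: the only measured step, no change at the digits printed from compound 1 to compound 2 (within the scatter), shows that exchanging one aromatic group for another on the saturated chain carbon bound to the amine nitrogen left growth inhibition unchanged within the scatter.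

Compound 3, `O=S(=O)(NCCCNCc1cccc2ccccc12)c1cc(C(F)(F)F)cc(C(F)(F)F)c1`, is not yet measured. It differs from compound 2 by naphthalen-1-yl in place of 4-bromophenyl on a saturated chain carbon bound to an amine nitrogen. This change sits at the same place as the measured step, and so that step is the one that bears on it. Within the data shown here, since the single swap made there produced no change, the expectation for compound 3 is a step of about the same size, that is none beyond the scatter, in this assay. Among the measured compounds shown here, no measured step shows how a larger two-ring group behaves at this position, so the range around the estimate is kept wide. Compound 3 is therefore estimated at 1900 nM, between 700 nM and 5000 nM, which means an expected step of no change at the digits printed from compound 2 to compound 3 (within the scatter).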

Compound 3, concentration for 50% growth inhibition: 1400 nM
Beside the measured number, compound 3's estimate is 1.4-fold (0.13 log units) above it, and the stated range covers the measured number.
By their numbers in this assay, from the lowest: compounds 3, 1 and 2 (each within the scatter of the next).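

In this assay, the swap of the single-ring 4-bromophenyl for the two-ring naphthalen-1-yl on a saturated chain carbon bound to an amine nitrogen gives a 1.4-fold lower number from compound 2 to compound 3 (0.13 log units; within the scatter) and the swap of 3,4-dimethoxyphenyl for the same group gives a 1.4-fold lower number from compound 1 to compound 3 (0.13 log units; within the scatter) so the larger group also stays within the scatter. Until now this position had shown only an exchange of one single-ring aromatic group for another; it now also accepts an aromatic group of 10 heavy atoms with 2 six-membered rings without a step beyond the scatter, and all three compounds stand within the scatter of one another. No independent measurement is available here to account for this flat reading.

The compounds shown leave open how growth inhibition would respond at this position to a group without an aromatic ring, such as cyclohexyl, or to one carrying a carboxylic acid or a pyridine ring. They also leave open whether the same flat reading would hold with a longer chain in the shared core, or with a trifluoromethyl group replaced by a hydrogen.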